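The source may hold more compounds than are shown below. What is called first, only, known or untested is meant among the compounds shown, and "the series" means these compounds.

Compound 1 `C/N=C(\S)[C@]1(c2cccc(C(F)(F)F)c2)CCCC[S+]1[O-]` gives 800 nM
Compound 2 `C/N=C(\S)[C@]1(c2ccc3ccccc3c2)CCCC[S+]1[O-]` gives 2000 nM

Of these two compounds tested in a functional assay (aorta) for inhibition, with Rattus norvegicus as the target (a higher number here means a weaker inhibitor, a lower number a stronger inhibitor), compound 1 has the lower number and is therefore the stronger inhibitor, and its gap to compound 2 lies beyond the usual scatter. Compound 3 `C/N=C(\S)[C@]1(c2cccc(C(=O)O)c2)CCCC[S+]1[O-]` has not yet been measured. It keeps the core of compound 1 and differs in a single group, with carboxy in place of trifluoromethyl on an aromatic carbon and the new group meta to a large group. Among the measured compounds shown here, neither measured compound carries a carboxy group, and no measured pair isolates a change at this place, so the data offer no direct guide and the forecast is a judgement with a wide range. A step to a higher number, beyond the scatter, is expected in this assay and would mean a weaker inhibitor. The estimated change is a 10-fold higher number from compound 1 to compound 3 (1.00 log units; beyond the scatter) in this forecast. For compound 3 the estimate is 8000 nM with an expected range of 1500 nM to 40000 nM as the estimated span.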

Compound 3, concentration for 90% inhibition: > 30000 nM
Compound 3 ended at the assay's limit; the forecaster's own chance of this, stated with the estimate: 20%; at least 3.7-fold (0.57 log units) between middle value and limit.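

Compound 3 gives > 30000 nM in this assay, and this value is a limit of the assay, not a number. Carboxy in place of trifluoromethyl on an aromatic carbon, meta to a large group, gives an at least 37-fold higher number from compound 1 to compound 3 (1.57 log units; beyond the scatter), so this is the first single change at this place that can be read, and it shows that inhibition here depends strongly on which group the ring carries, with the swap taking the inhibitor from measurable activity to the end of the assay's range. The true size of the step remains unknown because the reading stops at the limit: the limit of > 30000 nM in this assay, at which 1 of the 3 values shown sits.

The compounds shown do not tell whether the loss belongs to the carboxylic acid as such or to the removal of trifluoromethyl, and a single pair cannot separate the two. As far as these compounds go, how a methyl ester, a primary amide or a nitrile on this same aromatic carbon would read in this assay stays open, as does whether any group at this place could improve on compound 1.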